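The source may hold more compounds than are shown below. What is called first, only, known or untested is meant among the compounds shown, and "the series" means these compounds.

Measured so far in a functional assay (Platelet, plasma) for inhibition, with Homo sapiens as the target; a higher number here means a weaker inhibitor, a lower number a stronger inhibitor:
- compound 1 `N#Cc1cc2c(nc1N1CC(C(=O)NS(=O)(=O)c3ccc(Cl)s3)C1)COC2=O`: 193000 nM
- compound 2 `N#Cc1cc2c(nc1N1CCC(C(=O)NS(=O)(=O)Cc3ccccc3F)CC1)COC2=O`: 23700 nM
- compound 3 `CC1(C(=O)NS(=O)(=O)Cc2ccc(F)cc2)CCN(c2nc3c(cc2C#N)C(=O)OC3)CC1`: 35400 nM

Compound 2 and compound 3 lie within the scatter of each other, so these two cannot be ranked. Compound 1 has a higher number than compound 2, and that gap lies beyond the scatter. Compound 2 is therefore among the stronger inhibitors of this small set, though all three values are high.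

The next compound is compound 4 `N#Cc1cc2c(nc1N1CCC(C(=O)NS(=O)(=O)Cc3cccc(F)c3)CC1)COC2=O`. It has 3-fluorophenyl in place of the 2-fluorophenyl of compound 2, on a saturated chain carbon bound to a sulfonyl sulfur: 3-fluorophenyl in place of 2-fluorophenyl on a saturated chain carbon bound to a sulfonyl sulfur. Within the data shown here, no pair of measured compounds differs in one place only, so the data give no direct measure of a change of this kind.

The nearest guide is compound 3 at 35400 nM, which also carries fluorine on its aromatic ring and stays within the scatter of compound 2. On that basis, no change beyond the scatter is expected in this assay, and the estimated step is a 1.1-fold higher number from compound 2 to compound 4 (0.04 log units; within the scatter). The expected value for compound 4 is 26000 nM, with an estimated range of 12000 nM to 55000 nM.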

Compound 4, half-maximal inhibitory concentration: 70500 nM
The estimate for compound 4 lay 2.7-fold (0.43 log units) below the measured number; the measured number lies above the stated range.
By their numbers in this assay, from the lowest: compounds 2, 3 and 4 (each within the scatter of the next, the first and the last beyond it); then compound 1.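

In this assay, among these compounds, 3-fluorophenyl in place of 2-fluorophenyl on a saturated chain carbon bound to a sulfonyl sulfur gives a 3.0-fold higher number from compound 2 to compound 4 (0.47 log units; beyond the scatter), a modest loss and the first comparison in which only one place differs. The two compounds have the same atoms, joined differently, so this place responds to the arrangement of the fluorophenyl group alone, with the 2-fluorophenyl compound the stronger inhibitor of the pair, though both numbers remain high. No measurement available here accounts for this step.

This is a single pair on a single background, so it sets no trend for the series, and it leaves open how far the same change would carry over to other parts of the series. An unsubstituted phenyl or a 2-chlorophenyl at the same place would show whether the 2-fluorophenyl of compound 2 holds any real advantage or whether the 3-fluorophenyl of compound 4 is what costs activity.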